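The compounds below may be only part of what the source reports. "The series", "measured", "known", "first", "only" and "open" are said of these compounds alone.

Measured in a functional assay on L1210 cells (Mus musculus) for inhibition, read by MTT assay; a higher number here means a weaker inhibitor, a lower number a stronger inhibitor:
compound 1 `N#CC1CN1C(=O)Nc1ccc(F)cc1`: 5900 nM
compound 2 `CC(C)(C)NC(=O)N1CC1C#N`: 457000 nM

In this assay compound 1 holds the lower of the two numbers, and the gap to compound 2 lies beyond the scatter. Compound 3 `N#CC1CN1C(=O)Nc1ccc([N+](=O)[O-])cc1` has nitro in place of fluoro on an aromatic carbon, and the count of that change is nitro in place of fluoro on an aromatic carbon. Among the compounds with values here, no measured pair shows this change, so the expectation is a judgement: a small step toward a lower number, possibly none beyond the scatter. The expected step is a 1.7-fold lower number from compound 1 to compound 3 (0.23 log units; within the scatter). For compound 3 the estimated value is 3500 nM, with an expected range of 1000 nM to 12000 nM.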

Compound 3, half-maximal inhibitory concentration: 2600 nM
The estimate for compound 3 lay 1.3-fold (0.13 log units) above the measured number; the range from low to high includes it.
By their numbers in this assay, from the lowest: compound 3; then compound 1; then compound 2.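

Nitro in place of fluoro on an aromatic carbon, para to a group of 8 heavy atoms, gives a 2.3-fold lower number from compound 1 to compound 3 (0.36 log units; beyond the scatter) in this assay, so this position tolerates a larger group without loss. The change also moves the number beyond the scatter, which shows that the group at this position matters, though the step is modest. Nothing available explains the step. Only fluoro and nitro have been compared at this carbon. An amine, a methoxy group or a carboxylic acid there could show whether the lower number holds for other groups.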